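From Cyclopropyl to 4-Methoxyphenyl at the Ketone

This account rests on a few compounds, and the source may have more. Where it says the series, first, only, none or still open, it means among the compounds named here.

Three compounds were measured in a functional assay on PC-3 cells (Homo sapiens) for cytotoxicity, read by MTT assay, with a stated time of 48 h; a higher number here means a weaker inhibitor, a lower number a stronger inhibitor:
compound 1 `COc1cc(-c2nnc3n2NC(c2ccco2)C(C(=O)c2cccs2)S3)cc(OC)c1OC` gives 46200 nM
compound 2 `COc1cc(-c2nnc3n2NC(c2ccco2)C(C(=O)c2ccc(Cl)cc2)S3)cc(OC)c1OC` gives 67800 nM
compound 3 `COc1cc(-c2nnc3n2NC(c2ccco2)C(C(=O)C2CC2)S3)cc(OC)c1OC` gives 95200 nM

Compound 3 has the highest number of the three, beyond the scatter from compound 1 but within it from compound 2. Compound 4 `COc1ccc(C(=O)C2Sc3nnc(-c4cc(OC)c(OC)c(OC)c4)n3NC2c2ccco2)cc1` differs from compound 3 by 4-methoxyphenyl in place of cyclopropyl on a carbonyl carbon. The relevant comparisons are a 2.1-fold higher number from compound 1 to compound 3 (0.31 log units; beyond the scatter) and a 1.4-fold higher number from compound 2 to compound 3 (0.15 log units; within the scatter): both aryl or heteroaryl ketones gave lower numbers than the cyclopropyl ketone, one modestly, one within the scatter. Since 4-methoxyphenyl is again a six-membered aromatic ring on the carbonyl carbon, a modest lowering is expected, a 1.6-fold lower number from compound 3 to compound 4 (0.20 log units; within the scatter). Compound 4 is therefore estimated at 60000 nM, ranging from 30000 nM to 120000 nM.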

Compound 4, half-maximal inhibitory concentration: > 100000 nM
Compound 4 was reported as a limit; the forecaster's own chance of this, stated with the estimate: 10%; middle value at least 1.6-fold (0.22 log units) away from the limit.
By their numbers in this assay, from the lowest: compounds 1, 2 and 3 (each within the scatter of the next, the first and the last beyond it). At a limit, above all of these: compound 4.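

In this assay compound 4 is reported only as a limit, > 100000 nM. The comparison with the thiophen-2-yl ketone goes beyond the scatter, an at least 2.1-fold higher number from compound 1 to compound 4 (0.33 log units; beyond the scatter), so this position does not reward every aromatic ring on the carbonyl carbon. The other two steps, an at least 1.0-fold higher number from compound 3 to compound 4 (0.02 log units; that floor lies within the scatter) and an at least 1.4-fold higher number from compound 2 to compound 4 (0.16 log units; that floor lies within the scatter), give only floors within the scatter, so 4-methoxyphenyl shows no gain over cyclopropyl or 4-chlorophenyl.

From the compounds shown here alone, the true size of these steps remains open. So does whether an amine or a longer chain on the carbonyl carbon would fare better than thiophen-2-yl.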